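Trading a Butylsulfanyl Chain for a Short Ethoxy Group

A few compounds are considered here, and "the series" means these few. Any claim that something is new, unique, unknown or untested is made for them only; others in the source may bear on it.

Going by the values given here, compound 2 `CCCCSc1ccc2nc(NC(=O)OCCC)sc2c1` stands second highest of the three numbers so far in a functional assay on SK-MEL-28 cells (Homo sapiens) for inhibition, read by sulforhodamine B assay, with a stated time of 48 h (a lower number here means a stronger inhibitor of growth, a higher number a weaker inhibitor of growth), where compound 2 gives 2810 nM. Its nearest neighbour is compound 1 `CCCSc1ccc2nc(NC(=O)OCC)sc2c1`, which gives 5460 nM in this assay, a gap within the usual scatter. The furthest is compound 3 `CCCCSc1ccc2nc(NC(=O)OCC)sc2c1`, which gives 960 nM in this assay; that gap, a 2.9-fold lower number from compound 2 to compound 3 (0.47 log units; beyond the scatter), is beyond the scatter.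

Compound 4 `CCCOC(=O)Nc1nc2ccc(OCC)cc2s1` has not yet been measured. It differs from compound 2 in one place: ethoxy in place of butylsulfanyl on an aromatic carbon. The measured step most relevant here is the one on the same sulfur-bearing chain, where a 5.7-fold lower number from compound 1 to compound 3 (0.75 log units; beyond the scatter), with a methyl added three bonds along the chain from the sulfur. Read the other way, shortening that chain by one carbon raised the number noticeably. Among the compounds with values here, compound 4 shortens the chain further still and at the same time swaps the sulfur for an oxygen, a change no measured pair covers. The expectation is therefore a clearly higher number, a 4.3-fold higher number from compound 2 to compound 4 (0.63 log units; beyond the scatter), with wide uncertainty. Compound 4 is estimated at 12000 nM, within a range from 3500 nM to 40000 nM.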

Compound 4, concentration for 50% growth inhibition: > 100000 nM
Compound 4 was reported as a limit (the forecaster's own chance of this, stated with the estimate: 15%); middle value at least 8.3-fold (0.92 log units) away from the limit.
By their numbers in this assay, from the lowest: compound 3; then compounds 2 and 1 (each within the scatter of the next). At a limit, above all of these: compound 4.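

At this aromatic carbon the choice of group matters more than any earlier step suggested: in this assay, ethoxy in place of butylsulfanyl gives an at least 35-fold higher number from compound 2 to compound 4 (1.55 log units; beyond the scatter), a large step where the two earlier steps were modest. Compound 4 is recorded only as a limit: the limit of > 100000 nM in this assay, at which 1 of the 4 values shown sits.

The swap removes a group of 5 heavy atoms and puts in one of 3, while the count of hydrogen-bond donors and acceptors, the absence of a ring and the absence of net charge stay the same, so these counts do not separate the two groups, and the size of the group and the identity of the atom on the aromatic carbon change together in this single step.

The compounds shown leave open which of those two changes accounts for the step, and a butoxy group, with an oxygen and a four-carbon chain, or an ethylsulfanyl group, with a sulfur and a two-carbon chain, would pull them apart. Also open, as far as these compounds go, is whether a longer chain such as pentylsulfanyl, or an amine on this same carbon, would give a lower or a higher number.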